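A solubility step from compound 1 to compound 4

The compounds below may be only part of what the source reports. "The series", "measured", "known", "first", "only" and "open" are said of these compounds alone.

Compound 1 `COc1cccc(CNCCCNc2ccnc3cc(Oc4ccc(F)cc4)ccc23)c1O` was measured in a physicochemical assay for solubility, with a stated time of 18 h, at pH 7.4 (on this read-out higher numbers stand for higher solubility and lower numbers for lower solubility), where compound 1 gives 14500 nM. Compound 2 `Fc1ccc(Oc2ccc3c(NCCCNCc4ccco4)ccnc3c2)cc1` gives 14500 nM, and compound 3 `COc1ccc(F)cc1CNCCCNc1ccnc2cc(CC(C)C)ccc12` gives 4200 nM. On these numbers compound 1 stands level with compound 2 at the digits shown, the two of them together the highest of the three, while compound 3 sits furthest away with a lower number that lies beyond the scatter.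

Among the measured compounds shown here, the one step between two measured compounds that differ in a single place runs from compound 1 to compound 2: no change at the digits printed from compound 1 to compound 2 (within the scatter), a change that sits on the chain nitrogen side of the shared core.

For the measured compounds named here, compound 4 `COc1cccc(CNCCCNc2ccnc3cc(Cc4ccc(C#N)cc4)ccc23)c1O` has not yet been measured. 4-cyanobenzyl in place of 4-fluorophenoxy on an aromatic carbon This change sits on the fused ring side of the core and has no counterpart among the measured steps; the step from compound 1 to compound 2 touched a different part of the molecule and left this assay unchanged. Compound 3 carries a different group at that place together with a second change, so only its value can be compared, not a single step.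

Going by the values given here, with no direct precedent, compound 4 is expected to give 10000 nM, within a range from 3000 nM to 30000 nM, a step of a 1.5-fold lower number from compound 1 to compound 4 (0.16 log units; within the scatter) that is not expected to clear the scatter.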

Compound 4, solubility: 4200 nM
For compound 4 the middle estimate is 2.4-fold (0.38 log units) above the measured one; measured number inside the range.
By their numbers in this assay, from the lowest: compounds 3 and 4 (each within the scatter of the next); then compounds 1 and 2 (each within the scatter of the next).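

In this assay, putting 4-cyanobenzyl in place of 4-fluorophenoxy on an aromatic carbon of the shared core gives a 3.5-fold lower number from compound 1 to compound 4 (0.54 log units; beyond the scatter). This is the only single change shown that moves the number beyond the scatter, whereas the change on a saturated chain carbon bound to an amine nitrogen, furan-2-yl in place of 2-hydroxy-3-methoxyphenyl, gives no change at the digits printed from compound 1 to compound 2 (within the scatter), so this aromatic position responds where that chain position did not. Nothing measured here accounts for the size of the step, which therefore stands as an observation only.

The compounds shown leave open which part of the swap carries the step, the oxygen link of 4-fluorophenoxy against the carbon link of 4-cyanobenzyl or the fluorine against the nitrile, and a matched pair with 4-cyanophenoxy or 4-fluorobenzyl at this place would separate the two. Also open, going by these compounds, is whether the same step appears when furan-2-yl takes the place of 2-hydroxy-3-methoxyphenyl on the chain, as it does in compound 2.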